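Ring Enlargement on Two Cores in an A549 Cell Assay

This account rests on a few compounds, and the source may have more. Where it says the series, first, only, none or still open, it means among the compounds named here.

The measured compounds are:
compound 1, `CNC(=O)c1cc(Oc2ccc(Nc3nccc(N4CCCC4)n3)cc2)ccn1`, 3410 nM
compound 2, `CN(c1ccc(Oc2ncnc3sccc23)cc1)c1nccc(N2CCCC2)n1`, 15100 nM
compound 3, `CNC(=O)c1cc(Oc2ccc(Nc3nccc(N4CCCCC4)n3)cc2)ccn1`, 890 nM

The three compounds were tested in a functional assay on A549 cells (Homo sapiens) for inhibition, read by MTT assay, with a stated time of 72 h; on this read-out higher numbers stand for weaker inhibition and lower numbers for stronger inhibition. Compound 1 carries a pyrrolidin-1-yl group; compound 3 is its counterpart with a piperidin-1-yl group in its place. The change between them is piperidin-1-yl in place of pyrrolidin-1-yl on an aromatic carbon, and the step it made in this assay was a 3.8-fold lower number from compound 1 to compound 3 (0.58 log units; beyond the scatter). Compound 2 sits on a different core; how its core differs from that of compound 1 is not broken down here. In this assay compound 2 gives the highest of the three numbers, and its nearest neighbour is compound 1.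

Compound 4, `CN(c1ccc(Oc2ncnc3sccc23)cc1)c1nccc(N2CCCCC2)n1`, has not yet been measured. It is related to compound 2 in the same way that compound 3 is related to compound 1: the change is piperidin-1-yl in place of pyrrolidin-1-yl on an aromatic carbon, and it is made at the same place on the same kind of ring, so it counts as the same change. Among the compounds with values here, only one measured pair shows this change, so the expectation rests on a single step. If the change behaves on the core of compound 2 as it did on the core of compound 1, the step from compound 2 to compound 4 is expected to be about a 3.8-fold lower number from compound 2 to compound 4 (0.58 log units; beyond the scatter), because the earlier step was a 3.8-fold lower number from compound 1 to compound 3 (0.58 log units; beyond the scatter). On that basis compound 4 is estimated to give 4000 nM in this assay, with an expected range from 1500 nM to 11000 nM.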

Compound 4, half-maximal inhibitory concentration: 8790 nM
Compound 4: middle estimate off by 2.2-fold (0.34 log units), on the low side, within the range that was stated.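

Set side by side in this assay, the two steps for piperidin-1-yl in place of pyrrolidin-1-yl do not differ by more than repeated measurements would: the same change on two cores in this assay, a 3.8-fold lower number (0.58 log units; beyond the scatter) from compound 1 to compound 3 and a 1.7-fold lower number (0.23 log units; within the scatter) from compound 2 to compound 4, 2.2-fold (0.35 log units) apart, within the scatter of two such steps. Taken alone, however, the step on the second core, a 1.7-fold lower number from compound 2 to compound 4 (0.23 log units; within the scatter), cannot be told apart from no change at all, so the data do not establish that the larger ring lowers the number on that core as it did on the core of compound 1. The result is therefore compatible with the change carrying over from one core to the other, but it does not demonstrate this, since two pairs in one assay fix neither a common size for the step nor its direction on the second core.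

The compounds shown leave open how other groups on the same aromatic carbon would behave on the two cores, such as azepan-1-yl, morpholin-4-yl or an open-chain amine like dimethylamino. They also leave open whether the two steps would stay this close in any read-out other than this assay, or on any core beyond these two.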